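The source may report more compounds than this note shows. Statements on the series, on what has been measured and on what is new or still open speak of the compounds shown alone.

Measured in a functional assay on PANC-1 cells (Homo sapiens) for inhibition, read by MTT assay, with a stated time of 24 h; a lower number here means a stronger inhibitor, a higher number a weaker inhibitor:

Compound 1 `CC1(C)[C@H]2CC[C@]1(C)N(Cc1cn(-c3cccc(F)c3)nn1)C(=O)C2`: 220 nM
Compound 2 `CC1(C)[C@H]2CC[C@]1(C)N(Cc1cn(-c3ccccc3Br)nn1)C(=O)C2`: 280 nM
Compound 3 `CC1(C)[C@H]2CC[C@]1(C)N(Cc1cn(-c3cccc(C#N)c3)nn1)C(=O)C2`: 260 nM

Compound 3 gives the second highest of these three numbers, yet its gaps to the others, a 1.1-fold lower number from compound 2 to compound 3 (0.03 log units; within the scatter) and a 1.2-fold higher number from compound 1 to compound 3 (0.07 log units; within the scatter), both lie within the scatter, so the three compounds cannot be told apart. Compound 4 `CC1(C)[C@H]2CC[C@]1(C)N(Cc1cn(-c3ccccc3Cl)nn1)C(=O)C2` differs from compound 3 by 2-chlorophenyl in place of 3-cyanophenyl on an aromatic nitrogen. Among the compounds with values here, the steps that bear on this are a 1.3-fold higher number from compound 1 to compound 2 (0.10 log units; within the scatter), which moved to a 2-halophenyl group, and a 1.1-fold lower number from compound 2 to compound 3 (0.03 log units; within the scatter), which left one; neither exceeded the scatter. Compound 4 is therefore expected to show no step beyond the scatter, a 1.0-fold lower number from compound 3 to compound 4 (0.02 log units; within the scatter). Compound 4 is estimated at 250 nM, within 130 nM to 480 nM.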

Compound 4, half-maximal inhibitory concentration: 270 nM
Estimate against measurement, compound 4: 1.1-fold (0.03 log units) below; measured number inside the range.
By their numbers in this assay, from the lowest: compounds 1, 3, 4 and 2 (each within the scatter of the next).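

In this assay, 2-chlorophenyl on the aromatic nitrogen reads like the groups already seen there: a 1.0-fold higher number from compound 3 to compound 4 (0.02 log units; within the scatter), a 1.0-fold lower number from compound 2 to compound 4 (0.02 log units; within the scatter) and a 1.2-fold higher number from compound 1 to compound 4 (0.09 log units; within the scatter). Within the data shown here, the second of these steps is the first direct exchange of one halogen for another on an aromatic carbon, and it too stays within the scatter, so the four aryl groups cannot be told apart at this position. No measurement shown accounts for this flat reading. Still open, from the compounds shown here alone, is whether an amine or a carboxylic acid on the phenyl ring, or a longer chain in its place, would give a step beyond the scatter.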